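Demethylation in a fused pyridine growth-inhibitor series

This account rests on a few compounds, and the source may have more. Where it says the series, first, only, none or still open, it means among the compounds named here.

Compound 2 `Cc1ccnc2nc(-c3ccc(Cl)cc3)cc(O)c12` gives 1320 nM in a functional assay on MDA-N cells (Homo sapiens); a lower number here means a stronger inhibitor of growth, a higher number a weaker inhibitor of growth. Compound 1 `Oc1cc(-c2ccc(Cl)cc2)nc2ncccc12` gives 8320 nM in this assay. The step between them is a 6.3-fold higher number from compound 2 to compound 1 (0.80 log units; beyond the scatter); the change is hydrogen in place of methyl on an aromatic carbon. Compound 3 `COc1ccccc1-c1cc(O)c2ccc(C)nc2n1` gives 20000 nM in this assay, the highest number of the three, and the difference between its core and the core of compound 2 is not broken down here. Compound 4 `COc1ccccc1-c1cc(O)c2cccnc2n1` has not yet been measured in this assay. It differs from compound 3 by hydrogen in place of methyl on an aromatic carbon, the same kind of change as that from compound 2 to compound 1, though the place is not the same word for word: in compound 4 the methyl leaves a carbon next to the ring nitrogen, meta and para to the fused ring, whereas in compound 1 it leaves a carbon ortho and meta to the fused ring, opposite the ring nitrogen. Compound 4 is therefore expected to give 45000 nM in this assay, a step of a 2.3-fold higher number from compound 3 to compound 4 (0.35 log units; beyond the scatter), resting on the loss seen from compound 2 to compound 1 and on compound 3 already giving 20000 nM. The expected range for compound 4 is 15000 nM to 120000 nM.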

Compound 4, concentration for 50% growth inhibition: 20000 nM
Beside the measured number, compound 4's estimate is 2.3-fold (0.35 log units) above it, and the stated range covers the measured number.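

Hydrogen in place of methyl on an aromatic carbon does not carry a fixed size from one core to another in this series: the same change on two cores in this assay, a 6.3-fold higher number (0.80 log units; beyond the scatter) from compound 2 to compound 1 and no change at the digits printed (within the scatter) from compound 3 to compound 4, 6.3-fold (0.80 log units) apart, beyond the scatter of two such steps

With the methyl leaving a carbon next to the ring nitrogen, the reading in this assay is no change at the digits printed from compound 3 to compound 4 (within the scatter), so on this core the methyl at that place shows no measurable contribution to growth inhibition. The result does not show which difference between the two pairs accounts for the gap, as they differ both in the core and in the place of the methyl, and two pairs give no rule for any further core.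

Open, as far as these compounds go, is whether an ethyl, a methoxy or an amine on that same carbon would read like the methyl or the hydrogen on the core of compound 3. Also open, from the compounds shown here alone, is whether a methyl at the place it holds in compound 2 would show the same step on the core of compound 4.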